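This account rests on a few compounds, and the source may have more. Where it says the series, first, only, none or still open, it means among the compounds named here.

Measured compounds:
compound 1 `O=C(CC1c2ccccc2N=C(SCCCCCN2CCCC2)N1c1ccc(-c2ccc(F)cc2)cc1)NCc1ccccc1` — 2180 nM
compound 2 `CN(C)CCCCCSC1=Nc2ccccc2C(CC(=O)NCc2ccc(F)cc2)N1c1ccccc1` — 555000 nM
compound 3 `O=C(CC1c2ccccc2N=C(SCCCCCN2CCCC2)N1c1ccc(-c2ccccc2)cc1)NCc1ccccc1` — 660 nM

These three compounds were tested in an assay on cells for inhibition of Voltage-dependent T-type calcium channel subunit alpha-1G (Homo sapiens), read by patch clamp; a lower number here means a stronger inhibitor, a higher number a weaker inhibitor. Compound 3 gives the lowest of the three values, and compound 2 stands far from both of the others. Compound 1 and compound 3 share a core and differ in one place, (hydrogen in place of fluoro on an aromatic carbon); this step reads a 3.3-fold lower number from compound 1 to compound 3 (0.52 log units; beyond the scatter). Compound 2 has a different core, and the difference between the two cores is not broken down here.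

Compound 4 `CN(C)CCCCCSC1=Nc2ccccc2C(CC(=O)NCc2ccccc2)N1c1ccccc1` has not yet been measured in this assay. It is related to compound 2 by hydrogen in place of fluoro on an aromatic carbon. This is the same kind of change as that from compound 1 to compound 3: in both cases fluoro leaves and hydrogen enters on an aromatic carbon of a six-membered aromatic ring of carbon only, para to a large group. Cut one bond further out, however, the change from compound 1 to compound 3 reads 4-fluorophenyl to phenyl, while that from compound 2 to compound 4 reads 4-fluorobenzyl to benzyl, so the surroundings of the change are not the same.

Compound 4 is expected to show a step of a 1.9-fold lower number from compound 2 to compound 4 (0.27 log units; within the scatter), a modest one that rests on the direction and size of a 3.3-fold lower number from compound 1 to compound 3 (0.52 log units; beyond the scatter) but is discounted, that step having been seen on a different core and at a different ring. Compound 4 is therefore estimated at 300000 nM, within a range from 90000 nM to 1000000 nM.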

Compound 4, half-maximal inhibitory concentration: 18500 nM
Compound 4: the middle estimate sits 16-fold (1.21 log units) above what was measured, outside the stated range (below it).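

In this assay, replacing the fluoro of the 4-fluorobenzyl group with hydrogen gives a 30-fold lower number from compound 2 to compound 4 (1.48 log units; beyond the scatter) and so moves the number the same way as the fluoro-to-hydrogen change on the 4-fluorophenyl group of compound 1. The direction therefore carries from one core to the other in these two pairs, but the size does not: the same change on two cores in this assay, a 3.3-fold lower number (0.52 log units; beyond the scatter) from compound 1 to compound 3 and a 30-fold lower number (1.48 log units; beyond the scatter) from compound 2 to compound 4, 9.1-fold (0.96 log units) apart, beyond the scatter of two such steps. The two pairs cannot show why the sizes part, since they differ from each other in more than one place: the core changes, and the fluoro sits on a 4-fluorophenyl group in one pair and on a 4-fluorobenzyl group in the other, so the gap cannot be assigned to either difference, and two pairs set no rule for the wider series.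

The compounds shown leave open how a 4-fluorobenzyl group would behave on the core of compound 1 and a 4-fluorophenyl group on the core of compound 4, which would separate the place of the change from the core around it. They also leave open whether chloro or methoxy on the same aromatic carbon would follow the fluoro in either core.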